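A few compounds are considered here, and "the series" means these few. Any claim that something is new, unique, unknown or untested is made for them only; others in the source may bear on it.

Measured so far in an ADME assay on L1210/0 cells (Mus musculus) for cytotoxicity, with a stated time of 48 h; on this read-out higher numbers stand for weaker inhibition and lower numbers for stronger inhibition:
compound 1, `C=C(Br)[C@H]1O[C@@H](n2cnc3c(N)ncnc32)[C@@H](O)[C@H]1O`: 25000 nM
compound 2, `[N-]=[N+]=NCc1cn([C@H]2C[C@H](O)[C@@H](CO)O2)c(=O)[nH]c1=O`: 124000 nM

Compound 2 stands at the highest of the two numbers in this assay. Its nearest neighbour is compound 1, which gives 25000 nM in this assay; that gap lies beyond the usual scatter, so the two compounds are separated on this read-out. Going by the values given here, the two structures differ in more than one place, so no single-point step between measured compounds is available, and the gap cannot be assigned to any one feature.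

Compound 3, `CCCC/C=C\c1cn([C@H]2C[C@H](O)[C@@H](CO)O2)c(=O)[nH]c1=O`, has not yet been measured in this assay. It differs from compound 2 at one place: hex-1-en-1-yl in place of azidomethyl on an aromatic carbon. Among the compounds with values here, the measured pair gives no precedent for this particular exchange. With nothing in the data pointing either way, the step from compound 2 to compound 3 in this assay is expected to be none beyond the scatter, a 1.2-fold lower number from compound 2 to compound 3 (0.09 log units; within the scatter). The estimate for compound 3 in this assay is 100000 nM, expected to fall between 30000 nM and 300000 nM.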

Compound 3, half-maximal inhibitory concentration: > 200000 nM
Compound 3 ended at the assay's limit; the forecaster's own chance of this, stated with the estimate: 20%; middle value at least 2.0-fold (0.30 log units) away from the limit.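

In this assay, this aromatic carbon now has its first single-point step, with hex-1-en-1-yl in place of azidomethyl: an at least 1.6-fold higher number from compound 2 to compound 3 (0.20 log units; that floor lies within the scatter). Compound 3 gives > 200000 nM, which is a limit of the assay and not a number. The exchange therefore gives no sign of stronger inhibition at this position, but the printed floor lies within the scatter, so compound 3 is not shown to be separated from compound 2, and the full size of the step stays unread at the end of the range: the limit of > 200000 nM in this assay, at which 1 of the 3 values shown sits.

Open, from the compounds shown here alone, is which part of the exchange the read-out follows, the loss of azidomethyl or the arrival of the longer unsaturated chain, as a single step cannot divide the two. A saturated hexyl chain, a simple methyl, an amine or a carboxylic acid on the same aromatic carbon would show whether any group here gives a number clear of the limit and beyond the scatter from compound 2.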